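The source may report more compounds than this note shows. Statements on the series, on what has been measured and on what is new or still open speak of the compounds shown alone.

Working notes on the series. Compound 1 `O=c1oc2ccc(Br)cc2c(=O)n1-c1ccc(Br)cc1F` in an ADME assay on RAW264.7 cells (Mus musculus) for cytotoxicity, read by MTT assay, with a stated time of 24 h (a higher number here means that more compound is tolerated, a lower number that less compound is tolerated), gives 7200 nM for compound 1. Compound 2 `O=c1oc2ccc(Br)cc2c(=O)n1-c1ccc(Cl)cc1F` in this assay gives 7500 nM for compound 2. For the measured compounds named here, the one step measured so far, a 1.0-fold higher number from compound 1 to compound 2 (0.02 log units; within the scatter), exchanges halogens on the ring that carries the fluoro. On the two numbers available, compound 1 stands together with compound 2, the gap between them within the scatter, so neither is set apart.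

Compound 3 `O=c1oc2ccc(Cl)cc2c(=O)n1-c1ccc(Br)cc1F` is not yet measured. It differs from compound 1 by chloro in place of bromo on an aromatic carbon, the same halogen exchange as before but on the shared core rather than on the ring carrying the fluoro. Going by the values given here, the only step that bears on it is a 1.0-fold higher number from compound 1 to compound 2 (0.02 log units; within the scatter), which stayed within the scatter. No other change is available to weigh. The step expected in this assay is therefore none beyond the scatter, estimated as a 1.0-fold higher number from compound 1 to compound 3 (0.02 log units; within the scatter). Compound 3 is expected to give about 7500 nM in this assay, with a range from 4000 nM to 14000 nM.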

Compound 3, half-maximal cytotoxic concentration: 8100 nM
Compound 3: middle estimate off by 1.1-fold (0.03 log units), on the low side; the range from low to high includes it.
By their numbers in this assay, from the lowest: compounds 1, 2 and 3 (each within the scatter of the next).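

On the aromatic carbon of the shared core, meta to a fused ring and para to a fused ring, chloro in place of bromo gives a 1.1-fold higher number from compound 1 to compound 3 (0.05 log units; within the scatter) in this assay and so leaves the number within the scatter. The earlier step, a 1.0-fold higher number from compound 1 to compound 2 (0.02 log units; within the scatter), showed this only for the ring carrying the fluoro, so the same exchange has now stayed within the scatter at both halogen-bearing places in these compounds. Nothing at hand gives a reason for this result.

Only bromo and chloro are shown at this position, so it remains open whether an amine, a carboxylic acid or a longer chain there would leave the number within the scatter. Also open is how chloro at both places together would read in this assay, since each exchange is shown only alone.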